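The source may hold more compounds than are shown below. What is called first, only, known or untested is meant among the compounds shown, and "the series" means these compounds.

Working notes on the amide series sharing one core.

Compound 1 `O=C(Nc1cccc(-c2oc3cc(-c4ccc(F)cc4)ccc3c(=O)c2O)c1)c1ccc(F)cc1F` gives 20500 nM in a functional assay on A549 cells (Homo sapiens) for antiproliferative activity, read by CCK-8 assay, with a stated time of 72 h; a lower number here means a stronger inhibitor, a higher number a weaker inhibitor. Compound 2 `O=C(Nc1cccc(-c2oc3cc(-c4ccc(F)cc4)ccc3c(=O)c2O)c1)c1ccc(Br)cc1F` gives 46100 nM in this assay, and compound 3 `COc1ccc(C(=O)Nc2cccc(-c3oc4cc(-c5ccc(F)cc5)ccc4c(=O)c3O)c2)c(F)c1` gives 40000 nM. Among these three numbers compound 3 holds the second highest; its nearest neighbour is compound 2 and its furthest is compound 1, and both gaps sit within the scatter, shown by a 1.2-fold lower number from compound 2 to compound 3 (0.06 log units; within the scatter) and a 2.0-fold higher number from compound 1 to compound 3 (0.29 log units; within the scatter). Among the compounds with values here, the only step beyond the scatter is a 2.2-fold higher number from compound 1 to compound 2 (0.35 log units; beyond the scatter), and it is modest.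

Compound 4 `O=C(Nc1cccc(-c2oc3cc(-c4ccc(F)cc4)ccc3c(=O)c2O)c1)c1ccc([N+](=O)[O-])cc1` differs from compound 3 in one place: 4-nitrophenyl in place of 2-fluoro-4-methoxyphenyl on a carbonyl carbon. Within the data shown here, no measured step touches a nitro group, so the bearing of the earlier steps is indirect: they show that changing a substituent on this terminal ring shifts the number only modestly, as a 2.2-fold higher number from compound 1 to compound 2 (0.35 log units; beyond the scatter), a 2.0-fold higher number from compound 1 to compound 3 (0.29 log units; within the scatter) and a 1.2-fold lower number from compound 2 to compound 3 (0.06 log units; within the scatter) show. The expected step of a 1.3-fold lower number from compound 3 to compound 4 (0.10 log units; within the scatter) is therefore small, with no direction called beyond the scatter. Compound 4 is expected to give about 32000 nM, within a range from 12000 nM to 85000 nM.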

Compound 4, half-maximal inhibitory concentration: 2440 nM
Estimate against measurement, compound 4: 13-fold (1.12 log units) above; the measured number lies below the stated range.
By their numbers in this assay, from the lowest: compound 4; then compounds 1, 3 and 2 (each within the scatter of the next, the first and the last beyond it).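

The terminal ring on the carbonyl carbon is more sensitive than the earlier halogen and methoxy changes suggested: 4-nitrophenyl gives a 16-fold lower number from compound 3 to compound 4 (1.21 log units; beyond the scatter) and a 19-fold lower number from compound 2 to compound 4 (1.28 log units; beyond the scatter), both large, and an 8.4-fold lower number from compound 1 to compound 4 (0.92 log units; beyond the scatter), which is modest. All three steps run in the same direction and lie beyond the scatter, which makes compound 4 the strongest inhibitor of the four in this assay. This single change on the carbonyl carbon therefore moves the number much further than any step among compounds 1, 2 and 3.

Each of these steps removes a fluorine-bearing ring and brings in the nitro group at once, so the compounds shown do not separate the two changes, and they leave open whether an amine or a carboxylic acid in place of the nitro group would keep the gain. No data in hand explain the gain.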